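Adding chloro to the benzyl group of compound 2

The compounds below may be only part of what the source reports. "The series", "measured", "known", "first", "only" and "open" are said of these compounds alone.

In a functional assay on HL-60 cells (Homo sapiens) for inhibition, read by CCK-8 assay, with a stated time of 48 h, tested at 20 uM (on this read-out lower numbers stand for less inhibition of growth and higher numbers for more inhibition of growth at the one concentration tested), compound 2 `COc1ccc(S(=O)(=O)Oc2ccccc2/C=C(\C#N)C(=O)Nc2nnc(Cc3ccccc3)s2)cc1` gives 100%. Compound 1 `COc1ccc(S(=O)(=O)Oc2ccccc2/C=C(\C#N)C(=O)Nc2nnc(Cc3cccc4ccccc34)s2)cc1` gives 98%, level with it within the scatter, while compound 3 `N#C/C(=C\c1ccccc1OS(=O)(=O)c1ccc(Cl)cc1)C(=O)Nc1nnc(Cc2ccccc2)s1` gives 26%, far lower. Compound 2 therefore stands at the top of the numbers together with compound 1, with little room left for any rise.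

Compound 4 `COc1ccc(S(=O)(=O)Oc2ccccc2/C=C(\C#N)C(=O)Nc2nnc(Cc3ccc(Cl)cc3)s2)cc1` differs from compound 2 in one place: chloro in place of hydrogen on an aromatic carbon. Chloro takes the place of hydrogen on an aromatic carbon, turning benzyl into 4-chlorobenzyl.

For the measured compounds named here, two measured steps bear on this change. Phenyl in place of naphthalen-1-yl, the change made in the same part of the molecule, gave a number 2 percentage points higher from compound 1 to compound 2 (within the scatter), so a much larger swap there left the number unmoved. Chloro in place of methoxy gave a number 74 percentage points lower from compound 2 to compound 3 (beyond the scatter), a large step, but it lies elsewhere in the molecule and cannot simply be carried over. It does show that one small swap can cost much here, which keeps the lower end of the expectation wide.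

The expected change is small, namely a number 10 percentage points lower from compound 2 to compound 4 (within the scatter). For compound 4 the estimate is 90%, with an expected range from 60% to 100%.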

Compound 4, percent growth inhibition at one concentration: 99%
Beside the measured number, compound 4's estimate is 9 percentage points below it; the range from low to high includes it.
By their numbers in this assay, from the lowest: compound 3; then compounds 1, 4 and 2 (each within the scatter of the next).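

In this assay the addition of chloro reads as a number 1 percentage points lower from compound 2 to compound 4 (within the scatter), and the comparison with the larger ring system reads as a number 1 percentage points higher from compound 1 to compound 4 (within the scatter). Until now this end of the molecule had been tested only by exchanging one whole ring system for another, whereas these steps show that the number also holds when a single chlorine is placed on the aromatic ring, para to a large group. Phenyl, 4-chlorophenyl and naphthalen-1-yl at this place therefore give numbers level with one another among these compounds, all carrying the methoxy group on the other ring, but no measurement at hand explains this lack of change.

On these data alone, whether an amine or a carboxylic acid at this same place on the ring would keep the number as high remains open, as does the result of a longer chain linking this ring to the shared core. Compound 1, compound 2 and compound 4 all sit at the top of a read-out taken at one concentration, so any real difference in strength among them could stay hidden there, and testing at lower concentrations would be needed to reveal it.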